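This account rests on a few compounds, and the source may have more. Where it says the series, first, only, none or still open, it means among the compounds named here.

Measured in a functional assay on MES-SA/Dx5 cells (Homo sapiens) for inhibition, read by fluorescence, with a stated time of 72 h; on this read-out lower numbers stand for stronger inhibition and higher numbers for weaker inhibition:
- compound 1 `CCc1ccc(/C=N/NC(=S)Nc2ccc(OC)cc2)nc1`: 56 nM
- compound 2 `O=[N+]([O-])c1ccc(NC(=S)N/N=C/c2ccccn2)cc1`: 2750 nM; 2740 nM (2 entries)

Among the measured compounds shown here, compound 1 stands at 56 nM, the only number it has in this assay; a further entry for compound 1 gives no single number. The repeat entries for compound 2 agree closely: the several entries of compound 2 in this assay, 2750 nM; 2740 nM (2 entries). Compound 2 at 2750 nM; 2740 nM (2 entries) sits at a much higher number than compound 1 at 56 nM, so it is the much weaker inhibitor of the pair.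

Compound 3 `CCc1ccc(/C=N/NC(=S)Nc2ccc([N+](=O)[O-])cc2)nc1` keeps the core of compound 1 and carries nitro in place of methoxy on an aromatic carbon, para to a large group: nitro in place of methoxy on an aromatic carbon. For the measured compounds named here, no measured pair isolates this change. Going by the values given here, the only measured compound bearing nitro is compound 2 at 2750 nM; 2740 nM (2 entries), and on that thin basis a step beyond the scatter is expected in this assay, towards weaker inhibition. The expected change is a 5.0-fold higher number from compound 1 to compound 3 (0.70 log units; beyond the scatter). For compound 3 the estimated value is 280 nM, with an expected range of 60 nM to 1500 nM.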

Compound 3, half-maximal inhibitory concentration: 11100 nM
Estimate against measurement, compound 3: 40-fold (1.60 log units) below; the measured number lies above the stated range.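

In this assay, this place on the aromatic ring, para to a large group, proves highly sensitive to the group it carries: nitro in place of methoxy gives a 200-fold higher number from compound 1 to compound 3 (2.30 log units; beyond the scatter). This pair isolates the change directly, and it shows that the ethyl group on the shared core does not by itself keep the number low, as compound 3 stands at 11100 nM. Compound 2 also carries nitro but lacks the ethyl group, and its printed values are lower than that of compound 3, so with nitro in place the ethyl group brings no gain in this small set: the several entries of compound 2 in this assay, 2750 nM; 2740 nM (2 entries)

Going by these compounds, with only methoxy and nitro seen at this place, it remains open whether the step reflects something particular to nitro or the loss of methoxy, and an amine, a chlorine or an ethoxy group there would help separate the two. On these data alone, it also remains open how much the ethyl group contributes when methoxy is present, which a methoxy analogue without the ethyl group would show against compound 1.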